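The compounds below may be only part of what the source reports. "The series", "measured", "known", "first", "only" and "open" are said of these compounds alone.

Measured in a functional assay on HepG2 cells (Homo sapiens) for antiproliferative activity, read by MTT assay; on this read-out higher numbers stand for weaker inhibition and lower numbers for stronger inhibition:

Compound 1 `COc1ccc(OC)c(/C=N/c2c(C#N)ncn2Cc2ccccc2Cl)c1`: 20000 nM
Compound 2 `N#Cc1ncn(Cc2ccccc2Cl)c1/N=C/c1ccc(O)cc1`: 38200 nM
Compound 3 `COc1cc(/C=N/c2c(C#N)ncn2Cc2ccccc2Cl)ccc1O`: > 40000 nM

Compound 3 sits at the limit of > 40000 nM in this assay, at which 1 of the 3 values shown sits, so its entry is a limit of the assay and not a number. Its true position on the scale is therefore unknown.

The next compound is compound 4 `COc1ccc(/C=N/c2c(C#N)ncn2Cc2ccccc2Cl)cc1OC`. The change is methyl in place of hydrogen on an oxygen on an aromatic ring, or hydroxy to methoxy.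

Going by the values given here, no measured step makes exactly this change. The nearest is an at least 1.0-fold higher number from compound 2 to compound 3 (0.01 log units; that floor lies within the scatter), which adds a methoxy in place of hydrogen on an aromatic carbon. Its floor lies within the scatter, so it gives no firm size or direction. Among the compounds with values here, compound 1, which carries methoxy groups and no hydroxy, gives 20000 nM in this assay, the only value here from a compound without a hydroxy group. That single value points weakly towards a lower number once the hydroxy is capped.

The expected change is modest, an at least 1.4-fold lower number from compound 3 to compound 4 (0.15 log units; that floor lies within the scatter), and it may not exceed the scatter. For compound 4 the estimated value is 28000 nM, with an expected range of 12000 nM to 60000 nM.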

Compound 4, half-maximal inhibitory concentration: > 50000 nM
Compound 4: a limit, no number; the forecaster's own chance of this, stated with the estimate: 35%; middle value at least 1.7-fold (0.25 log units) away from the limit.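

In this assay, compound 3 and compound 4 both give limits rather than numbers, so the step between these two compounds cannot be read. The compounds shown leave open whether going from hydroxy to methoxy changes the number at all, in which direction, and where compound 3 and compound 4 truly stand on the scale.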